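Phenyl for Methyl on the Shared Core of Compound 2

The compounds below may be only part of what the source reports. "The series", "measured", "known", "first", "only" and "open" are said of these compounds alone.

Compound 1 `Cn1c(=O)[nH]c2c(cnn2-c2ccccc2N)c1=N`: 0%
Compound 2 `Cn1c(=O)[nH]c2c(cnn2-c2ccccc2)c1=N`: 30%

In an assay on membranes from brain for binding affinity to adenosine receptor A1 (Rattus norvegicus), read by radioligand binding, tested at 20 uM (a lower number here means less inhibition, a higher number more inhibition at the concentration tested (going by the name of the read-out)), compound 1 gives 0% and compound 2 gives 30%, so compound 2 stands highest of the two numbers. Going by the values given here, the only measured step, a number 30 percentage points higher from compound 1 to compound 2 (beyond the scatter), concerns hydrogen in place of amino on an aromatic carbon. Compound 3 `N=c1c2cnn(-c3ccccc3)c2[nH]c(=O)n1-c1ccccc1` differs from compound 2 by phenyl in place of methyl on an aromatic nitrogen. Among the compounds with values here, no measured step touches this aromatic nitrogen, so the two numbers give no direction for the change, and no step beyond the scatter is expected: no change at the digits printed from compound 2 to compound 3 (within the scatter). Compound 3 is therefore estimated at 30%, within a range from 0% to 65%.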

Compound 3, a percentage reported as inhibition, at one concentration (the size of the read-out at that concentration, not a potency): 25%
The estimate for compound 3 lay 5 percentage points above the measured number, and the stated range covers the measured number.
By their numbers in this assay, from the lowest: compound 1; then compounds 3 and 2 (each within the scatter of the next).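

Swapping methyl for phenyl on this aromatic nitrogen gives a number 5 percentage points lower from compound 2 to compound 3 (within the scatter) in this assay. Going by these compounds alone, the position therefore accepts a six-carbon aromatic ring in place of a single carbon with no real change in the read-out, something the earlier compounds could not show. No supporting measurement explains this result.

On these data alone, whether an amine, a carboxylic acid or a longer chain such as butyl on this nitrogen would shift the number stays open. So does whether phenyl would behave the same way alongside the amino group of compound 1.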